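Side-chain swap from compound 1 to compound 3

The source may hold more compounds than are shown below. What is called first, only, known or untested is meant among the compounds shown, and "the series" means these compounds.

In a functional assay on A549 cells (Homo sapiens) for cytotoxicity, read by MTT assay, with a stated time of 48 h (a higher number here means a weaker inhibitor, a lower number a stronger inhibitor), compound 1 (`O=c1cc(-c2ccccc2)oc2c(OCCCCNC3CCCCC3)c(O)cc(O)c12`) has no number and stands as "not determined" (no result reported) without a result. Compound 2 (`COc1c(OCc2nc3ccccc3[nH]2)cc(O)c2c(=O)cc(-c3ccccc3)oc12`) gives > 100000 nM as a limit of the assay and not a number. Compound 3 (`CCN(CC)CCCOc1c(O)cc(O)c2c(=O)cc(-c3ccccc3)oc12`) carries diethylamino in place of (cyclohexylamino)methyl on a saturated chain carbon, three bonds along the chain from an oxygen on an aromatic ring. Without a value for compound 1, no measured anchor exists, and a step beyond the scatter in either direction is not expected in this assay on this change alone. Expected for compound 3 is 30000 nM with an estimated range of 8000 nM to 100000 nM as the likely outcome.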

Compound 3, half-maximal inhibitory concentration: > 100000 nM
Compound 3 gave a limit, no number; the forecaster's own chance of this, stated with the estimate: 25%; middle value at least 3.3-fold (0.52 log units) from the limit.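

Among the compounds shown here, compound 1 has no result and compound 3 gives only a limit, so no step between them can be read in this assay. Whether any side chain on the shared core gives a numerical value in this assay stays open: the limit of > 100000 nM in this assay, at which 2 of the 3 values shown sit.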